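The source may hold more compounds than are shown below. What is called first, only, known or untested is meant among the compounds shown, and "the series" means these compounds.

Working notes on the series. Going by the values given here, compound 3 `CC(C)(C)c1ccc(-c2cc(N3CCC(CCNS(N)(=O)=O)CC3)ncn2)cc1` gives 10300 nM in a functional assay on HT-29 cells (Homo sapiens) for antiproliferative activity, read by sulforhodamine B assay, with a stated time of 48 h (a higher number here means a weaker inhibitor of growth, a lower number a stronger inhibitor of growth), the second highest of the three numbers measured so far; its nearest neighbour is compound 1 `CCOC(=O)c1ccc(-c2cc(N3CCC(CNS(N)(=O)=O)CC3)ncn2)cc1`, which gives 5700 nM in this assay, a gap within the scatter, and the furthest is compound 2 `NS(=O)(=O)NCCC1CCN(c2cc(-c3ccccc3)ncn2)CC1`, which gives 66500 nM in this assay, a gap beyond the scatter. Among the compounds with values here, the only single-point step measured so far, a 6.5-fold lower number from compound 2 to compound 3 (0.81 log units; beyond the scatter), puts a group on the carbocyclic aromatic ring in place of hydrogen. Compound 4 `CCOC(=O)c1ccc(-c2cc(N3CCC(CCNS(N)(=O)=O)CC3)ncn2)cc1` differs from compound 3 by ethoxycarbonyl in place of tert-butyl on an aromatic carbon. Within the data shown here, no measured step swaps one group for another at this position, so the step of a 6.5-fold lower number from compound 2 to compound 3 (0.81 log units; beyond the scatter) bears on it only indirectly, showing that this position is sensitive. Compound 1 carries the same ethoxycarbonyl as compound 4 on a shorter chain, and its value sits within the scatter of compound 3. A modest step toward a lower number is therefore expected, a 1.5-fold lower number from compound 3 to compound 4 (0.17 log units; within the scatter), and compound 4 is estimated at 7000 nM in this assay, within a range from 2500 nM to 20000 nM.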

Compound 4, concentration for 50% growth inhibition: 6800 nM
Estimate against measurement, compound 4: 1.0-fold (0.01 log units) above; the range from low to high includes it.
By their numbers in this assay, from the lowest: compounds 1, 4 and 3 (each within the scatter of the next); then compound 2.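

Going by these compounds alone, on an aromatic carbon para to a large group, the first direct swap of one group for another in this assay, a 1.5-fold lower number from compound 3 to compound 4 (0.18 log units; within the scatter), does not separate ethoxycarbonyl from tert-butyl, even though ethoxycarbonyl carries 2 hydrogen-bond acceptors and tert-butyl carries 0. Against hydrogen at the same position, ethoxycarbonyl gives a 9.8-fold lower number from compound 2 to compound 4 (0.99 log units; beyond the scatter), so compounds 3 and 4 both stand apart from compound 2, while a 1.2-fold higher number from compound 1 to compound 4 (0.08 log units; within the scatter) shows that, with ethoxycarbonyl in place, (sulfamoylamino)methyl and sulfamoylamino on the saturated chain carbon cannot be told apart. No evidence on hand bears on the reason for these steps.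

From the compounds shown here alone, whether a carboxylic acid or an amine at this position would stay level with ethoxycarbonyl and tert-butyl remains open. Also open, going by these compounds, is whether a chain longer than that of compound 4 would leave the number unchanged.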